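The source may hold more compounds than are shown below. What is called first, only, known or untested is meant among the compounds shown, and "the series" means these compounds.

Compounds with numbers in hand:
compound 2, `CC(C)c1cc2c(N/N=C\c3ccccn3)ncnc2s1`, 0.003 ug/mL;
compound 3, `Cc1ccc(/C=N\Nc2ncnc3sc(C(C)(C)C)cc23)nc1`, 0.009 ug/mL;
compound 1, `CCc1cc2c(N/N=C\C3CC3)ncnc2s1`, "not determined" (no result reported).

Within the data shown here, in a functional assay on PC-6 cells (Homo sapiens) for antiproliferative activity (on this read-out higher numbers stand for weaker inhibition and lower numbers for stronger inhibition), compound 3 gives 0.009 ug/mL, the higher of the two numbers known; compound 2 gives 0.003 ug/mL, a lower number, and the gap between the two lies beyond the usual scatter. Compound 1 was not measured. Compound 4, `CC(C)(C)c1cc2c(N/N=C\c3cccc(CO)n3)ncnc2s1`, is the next step. It differs from compound 3 by 6-(hydroxymethyl)pyridin-2-yl in place of 5-methylpyridin-2-yl on a carbon with a double bond to nitrogen. Among the measured compounds shown here, no step of this kind has been measured here, so the account has nothing to scale it by. The step from compound 3 to compound 4 is expected to stay within the scatter, with the direction uncertain: a 1.1-fold higher number from compound 3 to compound 4 (0.05 log units; within the scatter). Compound 4 is therefore estimated at 0.01 ug/mL, within a range from 0.003 ug/mL to 0.04 ug/mL.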

Compound 4, half-maximal inhibitory concentration: 0.034 ug/mL
Compound 4: middle estimate off by 3.4-fold (0.53 log units), on the low side; the range from low to high includes it.
By their numbers in this assay, from the lowest: compound 2; then compound 3; then compound 4.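

In this assay, the change at this position gives a 3.8-fold higher number from compound 3 to compound 4 (0.58 log units; beyond the scatter) and so shows that the number responds to the group carried on the carbon with a double bond to nitrogen. This single step alters both the substituent and its numbered place on the pyridine ring, so the two contributions cannot be separated. Nothing measured here accounts for the shift. The compounds shown leave open how 6-methylpyridin-2-yl or 5-(hydroxymethyl)pyridin-2-yl would read at this place. They also leave open what an amine such as 6-(aminomethyl)pyridin-2-yl would give.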